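Trading a Benzyl Arm for a Phenoxy Arm on Compound 2

The source may report more compounds than this note shows. Statements on the series, on what has been measured and on what is new or still open speak of the compounds shown alone.

Compound 2 `CCOc1ccc(Cc2nnc(CN(c3ccccc3CC)S(=O)(=O)c3ccc(C)cc3)o2)cc1` holds the lowest of the two numbers in a functional assay on CHO cells for antagonist activity at prostaglandin E2 receptor EP1 subtype (Homo sapiens), read by FLIPR and calcium flux (a higher number here means a weaker inhibitor, a lower number a stronger inhibitor), giving 39.8 nM; compound 1 `CCc1ccccc1N(Cc1nnc(Cc2ccc(OC)cc2)o1)S(=O)(=O)c1ccc(C)cc1` gives 631 nM. Compound 3 `CCc1ccccc1N(Cc1nnc(Oc2ccc(OC)cc2)o1)S(=O)(=O)c1ccc(C)cc1` carries 4-methoxyphenoxy in place of 4-ethoxybenzyl on an aromatic carbon on the shared core. Among the compounds with values here, only one measured step bears on this change: a 16-fold lower number from compound 1 to compound 2 (1.20 log units; beyond the scatter), which added the same methyl that compound 3 again lacks. The swap of the benzyl link for a phenoxy link has no precedent among these compounds. The author therefore expects compound 3 to move back toward compound 1, with a 13-fold higher number from compound 2 to compound 3 (1.10 log units; beyond the scatter). The estimate for compound 3 in this assay is 500 nM, within 120 nM to 2000 nM.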

Compound 3, inhibition constant: 100 nM
Beside the measured number, compound 3's estimate is 5.0-fold (0.70 log units) above it, and the stated range ends above it.
By their numbers in this assay, from the lowest: compound 2; then compound 3; then compound 1.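

In this assay, the oxygen link holds up at this position: with the methoxy group kept, 4-methoxyphenoxy in place of 4-methoxybenzyl gives a 6.3-fold lower number from compound 1 to compound 3 (0.80 log units; beyond the scatter), while replacing 4-ethoxybenzyl gives a 2.5-fold higher number from compound 2 to compound 3 (0.40 log units; beyond the scatter). The link change alone therefore lowers the number, something the earlier pair could not show, yet compound 3 does not reach compound 2. Nothing available explains either shift. 

Open, on these data alone, is what 4-ethoxyphenoxy, joining the ethoxy group to the oxygen link, would give, and how an amine in place of the alkoxy group would read.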